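Amide nitrogen substituents on the shared core

A few compounds are considered here, and "the series" means these few. Any claim that something is new, unique, unknown or untested is made for them only; others in the source may bear on it.

Compound 2 `CCCCNC(=O)CC1CCc2cc(OC)c(OC)cc21` stands lowest of the three in a functional assay on the whole organism (strain Wistar) for inhibition, with Rattus norvegicus as the target, read by paw edema, with stated times of 60 min and 4 h, at a dose of 100 mg/kg by the oral route (a higher number here means more inhibition at the dose given (going by the name of the read-out), a lower number less inhibition), with 25%. Compound 1 `CCN(CC)C(=O)CC1CCc2cc(OC)c(OC)cc21` gives 37.5% and compound 3 `COc1cc2c(cc1OC)C(CC(=O)NC1CCCCC1)CC2` gives 50%. The shown steps are a number 12.5 percentage points lower from compound 1 to compound 2 (beyond the scatter) and a number 25 percentage points higher from compound 2 to compound 3 (beyond the scatter), both modest. Compound 4 `COc1cc2c(cc1OC)C(CC(=O)NCCO)CC2` carries hydroxy in place of ethyl on a saturated chain carbon, two bonds along the chain from an amide-type nitrogen. Within the data shown here, no measured step introduces a hydroxy, so the two amide steps bear only loosely: they show that the group on the amide-type nitrogen moves this assay by modest amounts in either direction. A step near the scatter is therefore expected from compound 2 to compound 4, namely a number 5 percentage points higher from compound 2 to compound 4 (within the scatter). Compound 4 is estimated at 30%, with a range from 15% to 45%.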

Compound 4, a percentage reported as inhibition, in the whole organism at one dose (the size of the read-out at that dose, not a potency): 9.37%
Compound 4: middle estimate off by 20.6 percentage points, on the high side; the whole stated range lies above it.
By their numbers in this assay, from the lowest: compound 4; then compound 2; then compound 1; then compound 3.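

In this assay, hydroxy in place of ethyl gives a number 15.6 percentage points lower from compound 2 to compound 4 (beyond the scatter), showing that a change on this chain can take the read-out below that of compound 2, already the lowest of the earlier amides. Against the other two amides, the 2-hydroxyethyl group gives a number 40.6 percentage points lower from compound 3 to compound 4 (beyond the scatter) and a number 28.1 percentage points lower from compound 1 to compound 4 (beyond the scatter), leaving compound 4 lowest of the four. No measurement shown accounts for this drop.

This change shortens the chain and adds the hydroxy together, and the two remain unseparated. A methoxy or an amine at the chain end, or a longer chain ending in hydroxy, would bear on this.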